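Amide variation on a shared core: pyrrolidine amide

The source may hold more compounds than are shown below. What is called first, only, known or untested is meant among the compounds shown, and "the series" means these compounds.

Measured so far in a functional assay on HepG2 cells (Homo sapiens) for antiproliferative activity, read by CCK-8 assay, with a stated time of 48 h; a lower number here means a stronger inhibitor, a higher number a weaker inhibitor:
compound 1 `COc1ccc(NC(=O)c2cc(Oc3ccc(/C=C/c4ccccn4)cc3)ccn2)cc1`: 30000 nM
compound 2 `O=C(NCc1ccccc1)c1cc(Oc2ccc(/C=C/c3ccccn3)cc2)ccn1`: 27900 nM
compound 3 `O=C(NCc1ccc(F)cc1)c1cc(Oc2ccc(/C=C/c3ccccn3)cc2)ccn1`: 45100 nM

All three compounds share one core and differ only in the group on the amide nitrogen. Compound 3 stands within the scatter of both others: a 1.5-fold higher number from compound 1 to compound 3 (0.18 log units; within the scatter) and a 1.6-fold higher number from compound 2 to compound 3 (0.21 log units; within the scatter), while a 1.1-fold lower number from compound 1 to compound 2 (0.03 log units; within the scatter). Going by the values given here, nothing among the measured steps separates these amides.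

Compound 4 `O=C(c1cc(Oc2ccc(/C=C/c3ccccn3)cc2)ccn1)N1CCCC1` is the next member. Its change from compound 3: pyrrolidin-1-yl in place of (4-fluorobenzyl)amino on a carbonyl carbon. Among the compounds with values here, the three measured steps bear on it only loosely, since each swaps one amide substituent for another while keeping the hydrogen-bond donor; compound 4 has none, and no measured pair shows that change. Given that every measured step here is within the scatter, no step beyond the scatter is expected for compound 4 in this assay, with the range widened for the untested loss of the donor.

Compound 4 is therefore expected to give 40000 nM, between 15000 nM and 110000 nM, which means an expected step of a 1.1-fold lower number from compound 3 to compound 4 (0.05 log units; within the scatter).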

Compound 4, half-maximal inhibitory concentration: 27000 nM
Compound 4: middle estimate off by 1.5-fold (0.17 log units), on the high side, and the stated range covers the measured number.
By their numbers in this assay, from the lowest: compounds 4, 2, 1 and 3 (each within the scatter of the next).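

On the carbonyl carbon, pyrrolidin-1-yl brings the first loss of the amide hydrogen in this set, yet in this assay the result stays within the scatter of all three amides that keep it (a 1.7-fold lower number from compound 3 to compound 4 (0.22 log units; within the scatter); a 1.0-fold lower number from compound 2 to compound 4 (0.01 log units; within the scatter); a 1.1-fold lower number from compound 1 to compound 4 (0.05 log units; within the scatter)). The change also removes the six-membered aromatic ring of the substituent and brings a five-membered non-aromatic ring with fewer heavy atoms, so neither the donor nor that aromatic ring separates these compounds in this read-out. No measurement shown here offers a reason for this flat result.

Going by these compounds, it remains open whether a piperazine amide, a morpholine amide or a carboxylic acid on this carbonyl carbon would give a step beyond the scatter. Changes to the shared core outside the amide also remain open.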